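The source may report more compounds than this note shows. Statements on the series, on what has been measured and on what is new or still open speak of the compounds shown alone.

Compound 1 `CC(C)Oc1cccc(-c2ccc(C(=O)N(Cc3cccc(OCCCCCC(=O)O)c3)C(C)C)cc2)c1`: in an ADME assay on Raji cells (Homo sapiens) for cytotoxicity, read by CellTiter-Glo and resazurin assay, with a stated time of 72 h (a lower number here means that less compound is needed, a higher number that more compound is needed for the effect), compound 1 gives > 26000 nM, which is a limit of the assay and not a number.
Compound 2 `CC(C)N(Cc1cccc(OCCCCCC(=O)O)c1)C(=O)c1ccc(-c2ccc3cc[nH]c3c2)cc1`: in this assay compound 2 gives > 26000 nM, again a limit of the assay.
Compound 3 `COc1cc(OC)cc(-c2ccc(C(=O)N(Cc3cccc(OCCCCCC(=O)O)c3)C(C)C)cc2)c1`: in this assay compound 3 gives > 26000 nM, also a limit of the assay.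

Compound 1 thus stands only at a limit, and the same holds for the two compounds that share its core; all three sit at the limit of > 26000 nM in this assay, at which 3 of the 3 values shown sit. The changes of the aryl group at one end of the core give steps that cannot be read: a step that the two limits leave unreadable from compound 1 to compound 2 and a step that the two limits leave unreadable from compound 1 to compound 3. Compound 4 `CC(C)N(Cc1cccc(OCCCCCC(=O)O)c1)C(=O)c1ccc(-c2cccc(Cl)c2)cc1` differs from compound 1 by chloro in place of isopropoxy on an aromatic carbon. Among the measured compounds shown here, no measured step bears directly on this change, and the three values give no number at all, so no step beyond the scatter can be expected in this assay in either direction. The expected step is a step that the limit leaves unreadable from compound 1 to compound 4. In this assay the estimate for compound 4 is 40000 nM, with a range from 15000 nM to 100000 nM.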

Compound 4, half-maximal effective concentration: > 21900 nM
Compound 4 ended at the assay's limit; the forecaster's own chance of this, stated with the estimate: 85%; the middle value is on the limit's open side.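

Compound 4, like compound 1, compound 2 and compound 3, gives only a limit in this assay, and none of the steps from those three compounds to compound 4 can be read. The compounds shown leave open at what concentration any of them reaches the half-maximal effect, and whether the aryl group changes it.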